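Swapping the ring-amine substituent in a weak antiproliferative series

The compounds below may be only part of what the source reports. "The series", "measured", "known", "first", "only" and "open" are said of these compounds alone.

Measured compounds:
compound 1 `NC(=O)c1c(NC(=O)c2ccccc2Cl)sc2c1CCN(Cc1ccc([N+](=O)[O-])cc1)C2` gives 11400 nM in a functional assay on HL-60 cells (Homo sapiens) for antiproliferative activity, with a stated time of 24 h; on this read-out lower numbers stand for stronger inhibition and higher numbers for weaker inhibition
compound 2 `Cc1ccc(C(=O)Nc2sc3c(c2C(N)=O)CCN(Cc2c(Cl)cccc2Cl)C3)cc1` gives 10000 nM in this assay

Both numbers are high, so both compounds are weak inhibitors of cell growth, and the gap between compound 1 and compound 2 is within the scatter, so neither stands apart from the other. Compound 3 `COc1ccccc1NC(=S)N1CCc2c(sc(NC(=O)c3ccccc3Cl)c2C(N)=O)C1` keeps the shared core and differs from compound 1 only at the amine nitrogen in the ring: a group of 11 heavy atoms (8 carbon, 1 nitrogen, 1 oxygen, 1 sulfur; one six-membered aromatic ring of carbon only) in place of a group of 10 heavy atoms (7 carbon, 1 nitrogen, 2 oxygen; one six-membered aromatic ring of carbon only), on an amine nitrogen in a ring. For the measured compounds named here, no measured pair shows what such a change does here, and the two measured compounds differ from each other in more than one place, so nothing about this step can be read from them. The step from compound 1 to compound 3 is therefore expected to stay within the scatter, a 1.1-fold lower number from compound 1 to compound 3 (0.06 log units; within the scatter), with no clear direction. Compound 3 is estimated at 10000 nM, between 3000 nM and 30000 nM.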

Compound 3, half-maximal inhibitory concentration: 40900 nM
Estimate against measurement, compound 3: 4.1-fold (0.61 log units) below; measured number outside the range, above it.
By their numbers in this assay, from the lowest: compounds 2 and 1 (each within the scatter of the next); then compound 3.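

The amine nitrogen in the ring is not a silent position: in this assay, putting the new group in place of 4-nitrobenzyl gives a 3.6-fold higher number from compound 1 to compound 3 (0.55 log units; beyond the scatter) as a modest loss of inhibition, beyond the scatter. Compounds 1 and 2 could not show this, since they differ from each other in more than one place. The new group brings a hydrogen-bond donor that 4-nitrobenzyl lacks, but nothing measured here ties the loss to that donor or to any other feature.

For the compounds shown here, a single step shows only that this change weakens an already weak compound, so it leaves open which part of the new group matters. It also leaves open whether a plain benzyl group or a short chain ending in an amine on this nitrogen would give lower numbers.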